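One Added Methyl, With Only Limits to Go On

The source may report more compounds than this note shows. Statements on the series, on what has been measured and on what is new or still open speak of the compounds shown alone.

Of the compounds shown here, three built on a shared core have so far been tested in a functional assay on T47D cells (Homo sapiens) for antiproliferative activity, read by MTT assay, with a stated time of 72 h; on this read-out higher numbers stand for weaker inhibition and lower numbers for stronger inhibition. Compound 1 (`COc1cc(-c2nccn2C)cc(OC)c1OC`) gives > 100000 nM as a limit of the assay, not a number. Compound 2 (`COc1cc(-c2nccn2C(C)C)cc(OC)c1OC`) gives > 100000 nM as a limit too. Compound 3 (`COc1cc(-c2nccn2S(=O)(=O)c2ccccc2)cc(OC)c1OC`) gives > 100000 nM as a limit as well. Compound 3 therefore has no number of its own and stands with the other two at the limit of > 100000 nM in this assay, at which 3 of the 3 values shown sit.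

Compound 4 (`COc1cc(-c2nccn2S(=O)(=O)c2ccc(C)cc2)cc(OC)c1OC`) differs from compound 3 by a single small change, phenyl to 4-methylphenyl: methyl in place of hydrogen on an aromatic carbon. For the measured compounds named here, the only measured step between the compounds is a different change, isopropyl in place of methyl on an aromatic nitrogen, and it reads a step that the two limits leave unreadable from compound 1 to compound 2. That step offers no size to carry over. No growth inhibition has been recorded for this series in this assay because the limit of > 100000 nM in this assay, at which 3 of the 3 values shown sit, describes every result so far. The estimated change is a number no higher from compound 3 to compound 4 (the limit leaves the size open) and is expected to stay within the usual scatter. A further limit is the most likely report. For compound 4 the expected value is 100000 nM with an estimated range from 30000 nM to 200000 nM in this assay.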

Compound 4, half-maximal inhibitory concentration: > 100000 nM
Compound 4: no number, only a limit; the forecaster's own chance of this, stated with the estimate: 75%; the middle value lies on the limit itself.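

Compound 3 and compound 4 both give only a limit of the assay, so no size can be read for the step between them, phenyl to 4-methylphenyl. The compounds shown leave open whether any change to the shared core brings a measurable value in this assay, because every result so far reads the same: the limit of > 100000 nM in this assay, at which 4 of the 4 values shown sit.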